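A few compounds are considered here, and "the series" means these few. Any claim that something is new, unique, unknown or untested is made for them only; others in the source may bear on it.

Working notes on the series.

Compound 1 `CC(C)[C@@H](c1ccc(-c2ccc3cccc(F)c3c2)[nH]c1=O)[C@@H]1OC(=O)NC1=O` and compound 2 `CC(C)/C(=C1/OC(=O)NC1=O)c1ccc(-c2ccc3cccc(F)c3c2)[nH]c1=O` share the same core and have both been run in an assay on membranes from Chem-1 cells for displacement of a labelled ligand from prostaglandin E2 receptor EP3 subtype (Homo sapiens), read by scintillation counting, with a stated time of 2 h; a higher number here means a weaker inhibitor, a lower number a stronger inhibitor. Compound 1 gives 85 nM; compound 2 gives 140 nM. The gap between these two numbers lies within the usual scatter of repeated measurements, so neither can be called stronger than the other on what is in hand; compound 1 simply holds the smaller of the two numbers.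

Compound 3 `CC(C)[C@H](C[C@H]1SC(=O)NC1=O)c1ccc(-c2ccc3cccc(F)c3c2)[nH]c1=O` has not yet been measured in this assay. It differs from compound 1 in one place: (2,4-dioxo-1,3-thiazolidin-5-yl)methyl in place of 2,4-dioxo-1,3-oxazolidin-5-yl on a saturated chain carbon bound to an aromatic carbon and a saturated chain carbon. Going by the values given here, no step between two measured compounds covers a change of this kind, so there is no direct precedent for its size or direction.

The expectation for compound 3 is a modest move toward a weaker inhibitor, with the change from compound 1 to compound 3 estimated at a 1.9-fold higher number from compound 1 to compound 3 (0.27 log units; within the scatter). Compound 3 is accordingly expected to give about 160 nM in this assay, with a plausible range from 40 nM to 650 nM.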

Compound 3, inhibition constant: 8 nM
Estimate against measurement, compound 3: 20-fold (1.30 log units) above; the whole stated range lies above it.
By their numbers in this assay, from the lowest: compound 3; then compounds 1 and 2 (each within the scatter of the next).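

This position, on a saturated chain carbon bound to an aromatic carbon and a saturated chain carbon, turns out to be sensitive in this assay: (2,4-dioxo-1,3-thiazolidin-5-yl)methyl in place of 2,4-dioxo-1,3-oxazolidin-5-yl gives an 11-fold lower number from compound 1 to compound 3 (1.03 log units; beyond the scatter), whereas compounds 1 and 2 alone showed no separation beyond the scatter. The step comes with the ring size, the double bonds outside aromatic rings and the hydrogen-bond donor and acceptor counts all unchanged, so what differs is the heavy-atom make-up of the group, with sulfur entering and one ring oxygen leaving, together with the added methylene. No measurement in hand bears on the origin of this step.

Still open, on these data alone, is how the step divides over the ring change and the added methylene: (2,4-dioxo-1,3-oxazolidin-5-yl)methyl and 2,4-dioxo-1,3-thiazolidin-5-yl on the same carbon would separate the two. Also open, as far as these compounds go, is whether a longer chain to the ring, or a carboxylic acid in place of the ring, would stay near compound 3 at 8 nM in this assay.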